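A few compounds are considered here, and "the series" means these few. Any claim that something is new, unique, unknown or untested is made for them only; others in the source may bear on it.

Working notes on the series in an ADME assay on BaF3 cells (Mus musculus) for antiproliferative activity, read by CellTiter-Glo and CCK-8 assay, with a stated time of 72 h; on this read-out higher numbers stand for weaker inhibition of growth and lower numbers for stronger inhibition of growth. Compound 1 `Cc1ccc(Nc2ncc3c(n2)N(C)C(=O)N(c2cc(NC(=O)c4cccc(C(F)(F)F)c4)ccc2C)C3)cc1C` gives 3760 nM and stands lowest of the two numbers in hand. Compound 2 `Cc1ccc(NC(=O)c2cccc(C(F)(F)F)c2)cc1N1Cc2cnc(O[C@H]3CCN(C(=O)OC(C)(C)C)C3)nc2N(C)C1=O` gives 8380 nM, the nearest value. Compound 3 `Cc1ccc(Nc2ncc3c(n2)N(C)C(=O)N(c2cc(NC(=O)c4cccc(C(F)(F)F)c4)ccc2C)C3)cc1N(C)C` reaches only the assay limit of > 10000 nM, a limit rather than a number. Within the data shown here, the one measured step, an at least 2.6-fold higher number from compound 1 to compound 3 (0.42 log units; beyond the scatter), is small but beyond the scatter and runs toward weaker inhibition. Compound 4 `Cc1ccc(NC(=O)c2cccc(C(F)(F)F)c2)cc1N1Cc2cnc(OC3CCNCC3)nc2N(C)C1=O` differs from compound 1 by (piperidin-4-yl)oxy in place of (3,4-dimethylphenyl)amino on an aromatic carbon. Among the measured compounds shown here, no measured step covers this change; the aromatic ring leaves, as it does in compound 2, whose number sits above that of compound 1. An upward step is therefore expected, a 1.7-fold higher number from compound 1 to compound 4 (0.24 log units; within the scatter), with a fair chance of a limit (the limit of > 10000 nM in this assay, at which 1 of the 3 values shown sits). Compound 4 is estimated at 6500 nM, between 2500 nM and 16000 nM.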

Compound 4, concentration for 50% growth inhibition: > 10000 nM
Compound 4 was reported as a limit; the forecaster's own chance of this, stated with the estimate: 30%; at least 1.5-fold (0.18 log units) between middle value and limit.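

On the aromatic carbon between two ring nitrogen atoms, in this assay, (piperidin-4-yl)oxy in place of (3,4-dimethylphenyl)amino gives an at least 2.6-fold higher number from compound 1 to compound 4 (0.42 log units; beyond the scatter), a floor set by a limit, so this replacement costs growth inhibition. Piperidin-4-yl in place of 1-(tert-butoxycarbonyl)pyrrolidin-3-yl on the oxygen gives an at least 1.1-fold higher number from compound 2 to compound 4 (0.07 log units; that floor lies within the scatter), which settles no order, and the remaining step, between two limits, cannot be read. The top of the range now holds a further compound: the limit of > 10000 nM in this assay, at which 2 of the 4 values shown sit.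

Left open is whether the loss follows the oxygen link or the departure of the aromatic ring. A phenoxy group or a piperidin-4-ylamino group on this carbon would separate the two.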